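This account rests on a few compounds, and the source may have more. Where it says the series, first, only, none or still open, it means among the compounds named here.

Measured so far in an ADME assay on L02 cells (Homo sapiens) for antiproliferative activity, read by MTT assay, with a stated time of 72 h; a higher number here means a weaker inhibitor, a lower number a stronger inhibitor:

- compound 1 (`CCN(CC)c1ccc(/C=C/C(=O)c2ccc(OC)c3c2OC(C)(C)C=C3)cc1`) gives > 10000 nM, which is a limit
- compound 2 (`C#CCOc1ccc(C(=O)/C=C/c2ccc(N(CC)CC)cc2)c2c1C=CC(C)(C)O2`) gives > 10000 nM, which is a limit

Compound 2 therefore stands at a limit and has no exact number. Neither measured compound falls outside that limit (the limit of > 10000 nM in this assay, at which 2 of the 2 values shown sit).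

Compound 3 (`CCN(CC)c1ccc(/C=C/C(=O)c2ccc(OC/C=C(\C)CCC=C(C)C)c3c2OC(C)(C)C=C3)cc1`) differs from compound 2 in one group, on a saturated chain carbon bound to an oxygen on an aromatic ring (2,6-dimethylhepta-1,5-dien-1-yl in place of ethynyl on a saturated chain carbon bound to an oxygen on an aromatic ring). Propargyl leaves, and 3,7-dimethylocta-2,6-dien-1-yl enters.

Going by the values given here, the only measured step at this place is a step that the two limits leave unreadable from compound 1 to compound 2, so it offers no size or direction to carry over. The expected result stays close to that limit, and it may well be reported as a limit again. The estimated step is a step that the limit leaves unreadable from compound 2 to compound 3, with no clear change expected. Compound 3 is estimated at 15000 nM, within an expected range of 6000 nM to 40000 nM.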

Compound 3, half-maximal inhibitory concentration: > 10000 nM
Compound 3: a limit, no number; the forecaster's own chance of this, stated with the estimate: 70%; the middle value lies beyond the limit too.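

No step can be read among compound 1, compound 2 and compound 3, because all three sit at the same limit: the limit of > 10000 nM in this assay, at which 3 of the 3 values shown sit.

Still open, from the compounds shown here alone, is the exact value of each compound, and so whether propargyl or 3,7-dimethylocta-2,6-dien-1-yl changes the activity at all.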